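The compounds below may be only part of what the source reports. "The series", "measured", "known", "first", "only" and "open" are said of these compounds alone.

Measured to date in a physicochemical assay for solubility, read by nephelometry, measured as kinetic solubility, at pH 2, tested at 10 mg/mL; on this read-out lower numbers stand for lower solubility and higher numbers for higher solubility:
compound 1 `Cc1c(F)cccc1C(=O)Nc1ccccn1` gives 50 ug/mL
compound 2 `Cc1ccccc1C(=O)Nc1ccc(C#N)cn1` gives 6.3 ug/mL
compound 3 `Cc1ccccc1C(=O)Nc1ncccn1` gives 6.3 ug/mL

Compound 2 stands level with compound 3 at the digits shown, the two together the lowest of the three numbers; the gap between them lies within the scatter. Compound 1 sits furthest from compound 2, with a number higher by more than the scatter allows. For the measured compounds named here, no single-change step between measured compounds is available, so no measured step size guides the next move.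

Compound 4 `Cc1ccccc1C(=O)Nc1ccc(F)cn1` is to be measured in this assay. It differs from compound 2 by fluoro in place of cyano on an aromatic carbon. With no measured step of this kind in the series, only a small rise or none beyond the scatter is expected from compound 2 to compound 4, namely a 1.6-fold higher number from compound 2 to compound 4 (0.20 log units; within the scatter). Compound 4 is estimated at 10 ug/mL, within a range of 4 ug/mL to 40 ug/mL.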

Compound 4, solubility: 25 ug/mL
Beside the measured number, compound 4's estimate is 2.5-fold (0.40 log units) below it; low and high end bracket the measured number.
By their numbers in this assay, from the lowest: compounds 2 and 3 (each within the scatter of the next); then compounds 4 and 1 (each within the scatter of the next).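

Fluoro in place of cyano on an aromatic carbon, two atoms from the ring nitrogen, gives a 4.0-fold higher number from compound 2 to compound 4 (0.60 log units; beyond the scatter) in this assay, the first measured single-change step in the series. The read-out therefore responds to the group at this position, though a single pair supports this. Nothing measured here accounts for the step. Going by these compounds, whether an amine or a methoxy group at this position would read nearer compound 2 or compound 4 remains open. Also open, on these data alone, is whether the same exchange gives a similar step on other cores.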